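Shortening the selenium side chain of compound 2

The source may hold more compounds than are shown below. What is called first, only, known or untested is meant among the compounds shown, and "the series" means these compounds.

Values so far in a functional assay on HepG2 cells (Homo sapiens) for inhibition, read by MTT assay, with a stated time of 48 h; a higher number here means a weaker inhibitor, a lower number a stronger inhibitor (in order of compound number)
- compound 1 `C[Se]c1ccc(N(C)c2nc(C3CC3)nc3ccccc23)cc1` gives (32 nM)
- compound 2 `COc1ccc(N(C)c2nc(C)nc3ccccc23)cc1OCCCCCC[Se]C#N` gives (4890 nM)

Compound 2 holds the higher of the two numbers, and its gap to compound 1 lies beyond the scatter. Going by the values given here, the two differ in more than one place, so no single-change step is available yet.

Compound 3 `COc1ccc(N(C)c2nc(C)nc3ccccc23)cc1[Se]C` keeps the core of compound 2 and alters one substituent, on an aromatic carbon ortho to a methoxy group: a group of 2 heavy atoms (1 carbon, 1 selenium; no ring) in place of a group of 10 heavy atoms (7 carbon, 1 nitrogen, 1 oxygen, 1 selenium; no ring), on an aromatic carbon. A large step to a lower number in this assay is expected, beyond the scatter. That expectation rests only on compound 1 (32 nM), which also carries a small selenium group, so the support is thin. The estimated change is a 33-fold lower number from compound 2 to compound 3 (1.51 log units; beyond the scatter) as the expected step. For compound 3 the estimate is 150 nM, with an expected range from 20 nM to 1500 nM in this read-out.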

Compound 3, half-maximal inhibitory concentration: 17 nM
Beside the measured number, compound 3's estimate is 8.8-fold (0.95 log units) above it, outside the stated range (below it).
By their numbers in this assay, from the lowest: compounds 3 and 1 (each within the scatter of the next); then compound 2.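

In this assay, going by these compounds alone, replacing the 10-heavy-atom group with the 2-heavy-atom selenium group gives a 290-fold lower number from compound 2 to compound 3 (2.46 log units; beyond the scatter), the only single-change step so far. With the shared core held constant, this shows that the number depends strongly on the group at this position, on an aromatic carbon ortho to a methoxy group. No measurement shown here explains the size of this step.

The change alters chain length, the oxygen link and the nitrile together, so the contribution of each remains unresolved. A shorter chain ending in the same selenium and nitrile pair would address chain length, while a methylthio group at this position would address whether selenium itself is needed.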